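Urea-to-hydrazone swap on the quinoline hydroxamate series

A few compounds are considered here, and "the series" means these few. Any claim that something is new, unique, unknown or untested is made for them only; others in the source may bear on it.

Measured so far:
compound 1 `COc1cc2c(Oc3ccc(NC(=O)Nc4ccccc4)cc3)ccnc2cc1OCCCCCCC(=O)NO`, 1650 nM
compound 2 `COc1cc2c(Oc3ccc(NC(=O)Nc4cccc(C)c4)cc3)ccnc2cc1OCCCCCCC(=O)NO`, 2010 nM
compound 3 `COc1cc2c(Oc3ccc(NC(=O)Nc4ccccc4C(F)(F)F)cc3)ccnc2cc1OCCCCCCC(=O)NO`, 5280 nM

In a functional assay on A549 cells (Homo sapiens) for antiproliferative activity, read by MTT assay (on this read-out higher numbers stand for weaker inhibition and lower numbers for stronger inhibition), compound 3 gives the highest of the three numbers; compound 2 sits nearest and compound 1 furthest, both steps beyond the scatter. The two changes that reach compound 3 from the others are a 3.2-fold higher number from compound 1 to compound 3 (0.51 log units; beyond the scatter) and a 2.6-fold higher number from compound 2 to compound 3 (0.42 log units; beyond the scatter), while a 1.2-fold higher number from compound 1 to compound 2 (0.09 log units; within the scatter) stays within the scatter.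

Compound 4 is `COc1cc2c(Oc3ccc(NC(=O)N/N=C/c4ccccc4)cc3)ccnc2cc1OCCCCCCC(=O)NO`. Against compound 3 the change is a group of 8 heavy atoms (7 carbon, 1 nitrogen; one six-membered aromatic ring of carbon only) in place of a group of 10 heavy atoms (7 carbon, 3 fluorine; one six-membered aromatic ring of carbon only), on an amide-type nitrogen. Going by the values given here, no measured pair exchanges the aryl group on that nitrogen for an imine-linked aryl group, so the step has no direct precedent. What the series does show is that the trifluoromethyl-bearing ring carries the highest number, and that an unsubstituted phenyl ring in compound 1 lies lower. Compound 4 returns to an unsubstituted ring, but through a different linkage, so only a loose reading is possible.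

On balance compound 4 is expected to give a modestly lower number than compound 3, a step of about a 2.1-fold lower number from compound 3 to compound 4 (0.32 log units; beyond the scatter). The estimate for compound 4 in this assay is 2500 nM, with a range from 800 nM to 8000 nM.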

Compound 4, half-maximal inhibitory concentration: 3700 nM
The estimate for compound 4 lay 1.5-fold (0.17 log units) below the measured number; the range from low to high includes it.
By their numbers in this assay, from the lowest: compounds 1, 2, 4 and 3 (each within the scatter of the next, the first and the last beyond it).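

In this assay, compound 4 changes the link between the amide-type nitrogen and the aromatic ring rather than a substituent on that ring, and against the unsubstituted phenyl urea this gives a modest step: a 2.2-fold higher number from compound 1 to compound 4 (0.35 log units; beyond the scatter). Against the two substituted ureas the result does not clear the scatter, with a 1.8-fold higher number from compound 2 to compound 4 (0.27 log units; within the scatter) and a 1.4-fold lower number from compound 3 to compound 4 (0.15 log units; within the scatter), so the imine-linked phenyl group cannot be told apart from either the 3-methylphenyl or the 2-(trifluoromethyl)phenyl group at this position. Nothing available on the compounds shown gives a reason for these steps.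

From the compounds shown here alone, the series shows the hydrazone-type linkage only with an unsubstituted ring, so it remains open whether a methyl or trifluoromethyl group on that ring would shift the number as trifluoromethyl does from compound 1 to compound 3. Also open, going by these compounds, is how this position would respond to a pyridine ring in place of the phenyl ring, or to a saturated methylene-amine link in place of the imine.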